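A few compounds are considered here, and "the series" means these few. Any claim that something is new, unique, unknown or untested is made for them only; others in the source may bear on it.

Compounds measured so far in an assay on HEK293 cells for positive allosteric modulation of metabotropic glutamate receptor 3 (Rattus norvegicus), read by thallium flux, with a stated time of 2.5 min; on this read-out higher numbers stand for an effect only at larger amounts of compound and lower numbers for an effect already at smaller amounts:

compound 1 `Cc1c(OCCCCOc2ccc(F)c(C(=O)O)c2)ccc(C(=O)CC2CCCC2)c1O`: 2490 nM
compound 2 `Cc1c(OCCCCOc2ccc(F)c(C(=O)O)c2)ccc(C(=O)CC(C)(C)C)c1O`: 258 nM

Compound 1 stands highest of the two numbers; its nearest neighbour is compound 2, reached by a 9.7-fold lower number from compound 1 to compound 2 (0.98 log units; beyond the scatter), a change on the ketone side chain of the shared core.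

Compound 3 `Cc1ccc(C(=O)O)cc1OCCCCOc1ccc(C(=O)CC2CCCC2)c(O)c1C` differs from compound 1 elsewhere: 5-carboxy-2-methylphenyl in place of 3-carboxy-4-fluorophenyl on an oxygen on a saturated carbon. Within the data shown here, the one measured step concerns the chain bound to the carbonyl carbon, not the aryl group on the oxygen, so no step bears on this change. No direction is therefore expected beyond the scatter; the estimate is left wide. For compound 3 the estimate in this assay is 2500 nM, between 700 nM and 9000 nM, which means an expected step of a 1.0-fold higher number from compound 1 to compound 3 (0.00 log units; within the scatter).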

Compound 3, half-maximal effective concentration: > 10000 nM
Compound 3: no number, only a limit; the forecaster's own chance of this, stated with the estimate: 15%; middle value at least 4.0-fold (0.60 log units) away from the limit.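

Changing the aryl group on the oxygen on a saturated carbon moves the read-out, which the earlier step on the ketone side chain could not show: 5-carboxy-2-methylphenyl in place of 3-carboxy-4-fluorophenyl gives an at least 4.0-fold higher number from compound 1 to compound 3 (0.60 log units; beyond the scatter) in this assay. Compound 3 gives > 10000 nM, a limit and not a number, so the full size of this step stays unknown: the limit of > 10000 nM in this assay, at which 1 of the 3 values shown sits.

This single change alters both the fluorine and methyl substitution and the carboxy numbering, and the compounds shown do not separate these. From the compounds shown here alone, how a chloro group on that aryl ring, or a tetrazole in place of the carboxylic acid, would read remains open.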